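Adding a Hydroxy Group to Compound 1

The source may hold more compounds than are shown below. What is called first, only, known or untested is meant among the compounds shown, and "the series" means these compounds.

In a functional assay on PC-3 cells (Homo sapiens) for inhibition, read by sulforhodamine B assay (a lower number here means a stronger inhibitor of growth, a higher number a weaker inhibitor of growth), compound 1 `FC(F)(F)c1ccc(-c2ccc(-c3ccc(-c4nc5ccccc5[nH]4)cc3)cc2)cc1` gives 45200 nM. That number lies within the scatter of its two measured relatives, compound 2 `Oc1ccc(-c2ccc(-c3ccc(-c4nc5ccccc5[nH]4)cc3)cc2)cc1` at 47000 nM and compound 3 `Clc1cccc(-c2ccc(-c3ccc(-c4nc5ccccc5[nH]4)cc3)cc2)c1` at 33700 nM.

Compound 4 `Oc1cccc2[nH]c(-c3ccc(-c4ccc(-c5ccc(C(F)(F)F)cc5)cc4)cc3)nc12` differs from compound 1 in a single place: hydroxy in place of hydrogen on an aromatic carbon. In words, this is hydroxy in place of hydrogen on an aromatic carbon, turning 1H-benzimidazol-2-yl into 4-hydroxy-1H-benzimidazol-2-yl.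

Among the compounds with values here, no measured compound carries a change at this place, so the evidence is only indirect. The closest comparison puts a hydroxy group elsewhere on the molecule, in place of trifluoromethyl, and gives a 1.0-fold higher number from compound 1 to compound 2 (0.02 log units; within the scatter). Exchanging 4-(trifluoromethyl)phenyl for 3-chlorophenyl gives a 1.3-fold lower number from compound 1 to compound 3 (0.13 log units; within the scatter). Neither step points in a clear direction, so no step beyond the scatter is expected, although this expectation is loose.

The expected step is a 1.3-fold lower number from compound 1 to compound 4 (0.11 log units; within the scatter). For compound 4, the estimated value is 35000 nM, with an expected range of 12000 nM to 70000 nM.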

Compound 4, concentration for 50% growth inhibition: 2260 nM
Compound 4: middle estimate off by 15-fold (1.19 log units), on the high side; the measured number lies below the stated range.
By their numbers in this assay, from the lowest: compound 4; then compounds 3, 1 and 2 (each within the scatter of the next).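

In this assay, a single hydroxy group on this aromatic carbon, turning 1H-benzimidazol-2-yl into 4-hydroxy-1H-benzimidazol-2-yl, gives a 20-fold lower number from compound 1 to compound 4 (1.30 log units; beyond the scatter). The earlier changes touched only the 4-(trifluoromethyl)phenyl group, and even a hydroxy group placed there, in a 1.0-fold higher number from compound 1 to compound 2 (0.02 log units; within the scatter), stayed within the scatter, so the same group counts for much more at this new place than it did at the old one. Nothing measured here bears on the reason for this large step.

Going by these compounds, whether the hydroxy group itself is required remains open, as a methoxy group, an amine or a fluorine atom on the same carbon would test that. The compounds shown carry this hydroxy group only alongside 4-(trifluoromethyl)phenyl, so whether the step would hold with 3-chlorophenyl is also unknown.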